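Swapping One Ring Substituent on a Weakly Cytotoxic Core

The source may hold more compounds than are shown below. What is called first, only, known or untested is meant among the compounds shown, and "the series" means these compounds.

Compound 1 `C=CCn1c(=O)/c(=C\c2cccc(C)c2)[nH]c(=O)/c1=C\c1ccccc1OC` is the anchor of this small set. In a functional assay on A549 cells (Homo sapiens) for cytotoxicity, read by CCK-8 assay, with a stated time of 72 h (a lower number here means a stronger inhibitor, a higher number a weaker inhibitor), compound 1 gives 22700 nM, a weak effect, and it is the only numerical result available. A related compound, compound 2 `COc1ccccc1/C=c1/[nH]c(=O)/c(=C\c2ccccc2OC)[nH]c1=O`, was also run in this assay, where compound 2 is reported as "not active" (no number reported) with no number attached. Compound 1 therefore stands alone, and nothing can be said about how it ranks against compound 2 beyond the fact that compound 2 yielded no figure at all.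

Compound 3 `C=CCn1c(=O)/c(=C\c2ccccc2F)[nH]c(=O)/c1=C\c1ccccc1OC` differs from compound 1 in a single place: 2-fluorophenyl in place of 3-methylphenyl on a double-bonded chain carbon bound to an aromatic carbon. Within the data shown here, no measured pair in this set shows what such a change does, so the expectation rests on the single value for compound 1 and on the small size of the change. The step from compound 1 to compound 3 is expected to be modest and to stay within the usual scatter, as a 1.1-fold higher number from compound 1 to compound 3 (0.04 log units; within the scatter) expresses. Compound 3 is estimated at 25000 nM, with a plausible range from 8000 nM to 80000 nM, and some chance that only a limit is reported.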

Compound 3, half-maximal inhibitory concentration: "not active" (no number reported)
Nothing numeric was reported for compound 3, so the estimate cannot be set against anything.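

In this assay, among these compounds, compound 3 is reported as not active with no number, while compound 1 gives 22700 nM, so no step between them can be read. The compounds shown leave open how far 2-fluorophenyl in place of 3-methylphenyl shifts the effect of the shared core. No supporting measurement bears on this result.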